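A Smaller Halogenated Aryl Ring Replaces the Trifluoromethyl Aryl

The source may report more compounds than this note shows. Statements on the series, on what has been measured and on what is new or still open speak of the compounds shown alone.

Measured compounds:
Compound 2 `CCCNC(=O)c1cc(Oc2ccc(NC(=O)c3cc4cccnc4n(-c4ccc(Br)cc4)c3=O)cc2)ccn1` gives 5190 nM in a functional assay on U-87MG ATCC cells for antiproliferative activity against U-87 MG (Homo sapiens), read by MTT assay, with a stated time of 72 h; a higher number here means a weaker inhibitor, a lower number a stronger inhibitor.
Compound 3 `CCCNC(=O)c1cc(Oc2ccc(NC(=O)c3cc4cccnc4n(-c4ccc(C(F)(F)F)cc4Cl)c3=O)cc2)ccn1` gives 10900 nM in this assay.
Compound 1 `CCCNC(=O)c1cc(Oc2ccc(NC(=O)c3cc4cccnc4n(-c4ccc(Cl)cc4)c3=O)cc2)ccn1` gives "not determined" (no result reported) in this assay, so no number is available for it.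

Among the measured compounds shown here, compound 3 thus stands at the higher, weaker, of the two numbers available, with compound 2 as its only neighbour; the single measured step, a 2.1-fold higher number from compound 2 to compound 3 (0.32 log units; beyond the scatter), is that gap. Compound 4 `CCCNC(=O)c1cc(Oc2ccc(NC(=O)c3cc4cccnc4n(-c4ccc(F)c(Cl)c4)c3=O)cc2)ccn1` differs from compound 3 in one place: 3-chloro-4-fluorophenyl in place of 2-chloro-4-(trifluoromethyl)phenyl on an aromatic nitrogen. For the measured compounds named here, the only measured step that bears on this position is again a 2.1-fold higher number from compound 2 to compound 3 (0.32 log units; beyond the scatter), where a ring with more heavy atoms took the place of 4-bromophenyl and the number rose modestly. Compound 4 carries a ring with fewer heavy atoms than that of compound 3, as the counted difference shows, and so sits nearer to the 4-bromophenyl of compound 2, without matching either. With one step to go on, the expectation is a modest return toward the number of compound 2, though a change within the scatter cannot be ruled out. For compound 4 the expected step is a 1.8-fold lower number from compound 3 to compound 4 (0.26 log units; within the scatter). The estimate for compound 4 in this assay is 6000 nM, with a likely range from 2500 nM to 15000 nM.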

Compound 4, half-maximal inhibitory concentration: 3590 nM
Beside the measured number, compound 4's estimate is 1.7-fold (0.22 log units) above it, within the range that was stated.
By their numbers in this assay, from the lowest: compounds 4 and 2 (each within the scatter of the next); then compound 3.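

Removing the 2-chloro-4-(trifluoromethyl)phenyl ring in favour of 3-chloro-4-fluorophenyl gives a 3.0-fold lower number from compound 3 to compound 4 (0.48 log units; beyond the scatter) in this assay, so the earlier rise at this position can be reversed by changing the ring on the aromatic nitrogen. The other new comparison gives a 1.4-fold lower number from compound 2 to compound 4 (0.16 log units; within the scatter), which means that 3-chloro-4-fluorophenyl and 4-bromophenyl cannot be told apart here even though their halogens differ in kind and placement, and that compound 3 is the weakest of the three compounds with a number. No measurement at hand explains why these ring changes have the effects they do.

Compound 3 carries its 2-chloro and 4-(trifluoromethyl) groups together, so the compounds shown cannot reveal whether one of them, or only the pair, accounts for its weaker number. They also leave open how this assay would respond to a ring bearing an amine or a carboxylic acid in place of the halogens, since every ring shown carries only halogen or trifluoromethyl groups.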